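Dropping the Fluoro Group from an Inactive Parent

A few compounds are considered here, and "the series" means these few. Any claim that something is new, unique, unknown or untested is made for them only; others in the source may bear on it.

Compound 1 `Nc1cccc(-c2cn3nc(-c4ccc(F)cc4)sc3n2)c1`: >= 250000 nM
Compound 2 `C=C(Br)C(=O)Nc1cccc(-c2cn3nc(-c4ccc(F)cc4)sc3n2)c1`: 250 nM

In a functional assay on L1210 cells (Mus musculus) for inhibition, read by cell counting, with a stated time of 2 days (a lower number here means a stronger inhibitor, a higher number a weaker inhibitor), compound 1 gives >= 250000 nM, which is a limit of the assay rather than a number (the limit of >= 250000 nM in this assay, at which 1 of the 2 values shown sits). Compound 2, in this assay, gives 250 nM. Within the data shown here, the one measured step is an at least 1000-fold lower number from compound 1 to compound 2 (3.00 log units; beyond the scatter). Among the measured compounds shown here, it is the only comparison available, and it concerns a different part of the molecule from the change now considered.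

Compound 3 `Nc1cccc(-c2cn3nc(-c4ccccc4)sc3n2)c1` differs from compound 1 by hydrogen in place of fluoro on an aromatic carbon. For the measured compounds named here, no measured step bears on this change: the step from compound 1 to compound 2 alters the nitrogen, not the 4-fluorophenyl group, so it offers no guide to what the fluoro contributes. Going by the values given here, with compound 1 sitting at the limit and no step touching the fluoro, compound 3 is expected to show no step beyond the scatter, that is a number no higher from compound 1 to compound 3 (the limit leaves the size open). Compound 3 is therefore estimated at 250000 nM in this assay, within a range of 100000 nM to 600000 nM, most likely again reported only as a limit.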

Compound 3, half-maximal inhibitory concentration: 32000 nM
Compound 3: middle estimate off by 7.8-fold (0.89 log units), on the high side, outside the stated range (below it).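

In this assay, among these compounds, the change from 4-fluorophenyl to phenyl gives an at least 7.8-fold lower number from compound 1 to compound 3 (0.89 log units; beyond the scatter), and this is the first sign that the place para to a large group on this six-membered aromatic ring of carbon only has a bearing on the read-out, something the earlier step at the nitrogen could not show. Compound 1 gives >= 250000 nM, which is a limit of the assay and not a number. The step can therefore be read only as a minimum, and its full size stays unknown, because one of its two ends is that limit: the limit of >= 250000 nM in this assay, at which 1 of the 3 values shown sits.

What the compounds shown leave open is whether hydrogen in place of fluoro would also lower the number when the (1-bromoethenyl)carbonyl group sits on the nitrogen, as it does in compound 2, since the change is shown here only with the free amine. Also open, on these data alone, is how other groups at the same place, such as chloro or methoxy, would compare, as only fluoro and hydrogen appear there.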